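The source may hold more compounds than are shown below. What is called first, only, known or untested is meant among the compounds shown, and "the series" means these compounds.

Compound 1 `Cc1cc(-c2ccco2)cn2c(CSCCc3ccccc3)cnc12` and compound 2 `Cc1cc(-c2ccoc2)cn2c(CSCCc3ccccc3)cnc12` share one core, while compound 3 `Cc1cc(-c2ccco2)c2ncc(CSCCc3ccccc3)n2c1` and compound 4 `Cc1cc(-c2ccoc2)c2ncc(CSCCc3ccccc3)n2c1` share another; how the two cores differ is not broken down here. In an ADME assay on HEL cells (Homo sapiens) for cytotoxicity, with a stated time of 3 days (on this read-out higher numbers stand for lower toxicity in this test and lower numbers for higher toxicity in this test), compound 1 gives only a limit of the assay, > 4 ug/mL. In this assay compound 2 likewise gives only a limit, > 4 ug/mL. In this assay, within the data shown here, compound 3 gives 100 ug/mL, the only full number among the three.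

The change from compound 1 to compound 2 is furan-3-yl in place of furan-2-yl on an aromatic carbon, and its step, a step that the two limits leave unreadable from compound 1 to compound 2, cannot be read because of the limit of > 4 ug/mL in this assay, at which 2 of the 3 values shown sit. The change from compound 3 to compound 4 is furan-3-yl in place of furan-2-yl on an aromatic carbon: the same kind of change, though here the place is ortho to a fused ring, where in compound 1 it is para to a fused ring.

Among the measured compounds shown here, since the one measured step of this kind is unreadable, the expected step from compound 3 to compound 4 is estimated as no change at the digits printed from compound 3 to compound 4 (within the scatter), and it rests on compound 3 alone, which gives 100 ug/mL. In this assay compound 4 is therefore expected to give about 100 ug/mL, between 20 ug/mL and 200 ug/mL.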

Compound 4, minimum cytotoxic concentration: 100 ug/mL
The estimate for compound 4 equals the measured number at the digits printed, within the range that was stated.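

Where the furan ring sits ortho to a fused ring, putting furan-3-yl in place of furan-2-yl gives no change at the digits printed from compound 3 to compound 4 (within the scatter) in this assay. This single pair shows that, on this core, the point at which the furan is attached makes no visible difference to this cell toxicity read-out, but it says nothing about any other test. It does not show that the result carries from one core to the other, because the matching step from compound 1 to compound 2 on the other core cannot be read: the limit of > 4 ug/mL in this assay, at which 2 of the 4 values shown sit.

From the compounds shown here alone, whether the two furans also match on the core of compound 1 stays open until both compounds there have full numbers. Also open, going by these compounds, is how this read-out would respond to a phenyl ring or a morpholine in place of the furan, or to an ethyl group in place of the methyl group.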